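The source may hold more compounds than are shown below. What is called first, only, known or untested is meant among the compounds shown, and "the series" means these compounds.

Measured so far in an assay on tissue (HeLa cells) for inhibition of Indoleamine 2,3-dioxygenase 1 (Homo sapiens), read by spectrophotometry; on this read-out higher numbers stand for weaker inhibition and lower numbers for stronger inhibition:
compound 1 `O/N=C(/Nc1ccccc1)c1ccc2occc2c1` gives 19000 nM
compound 2 `O/N=C(/Nc1cccc(C(F)(F)F)c1)c1ccc2occc2c1` gives 1900 nM
compound 3 `O/N=C(/Nc1cccc(-c2ccccc2)c1)c1ccc2occc2c1` gives 11900 nM

Compound 1 stands highest of the three numbers; compound 3 is nearest, with a 1.6-fold lower number from compound 1 to compound 3 (0.20 log units; within the scatter), and compound 2 furthest, with a 10-fold lower number from compound 1 to compound 2 (1.00 log units; beyond the scatter). Compound 4 `O/N=C(/NCc1cccs1)c1ccc2occc2c1` differs from compound 1 by (thiophen-2-yl)methyl in place of phenyl on an amine nitrogen. Within the data shown here, no measured step touches the amine nitrogen: the two steps from compound 1 concern groups on the phenyl ring, as does the step between the other two (a 6.3-fold higher number from compound 2 to compound 3 (0.80 log units; beyond the scatter)). These show the series covering a modest span in this assay, but none bears on exchanging the phenyl itself. Among the measured compounds shown here, with no bearing step, no shift beyond the scatter is expected in either direction. Compound 4 is estimated at 14000 nM, range 3500 nM to 56000 nM, which corresponds to an expected step of a 1.4-fold lower number from compound 1 to compound 4 (0.13 log units; within the scatter).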

Compound 4, half-maximal inhibitory concentration: 16200 nM
Estimate against measurement, compound 4: 1.2-fold (0.06 log units) below; low and high end bracket the measured number.
By their numbers in this assay, from the lowest: compound 2; then compounds 3, 4 and 1 (each within the scatter of the next).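

In this assay, among these compounds, this is the first reading at the amine nitrogen itself: (thiophen-2-yl)methyl in place of phenyl leaves the number within the scatter (a 1.2-fold lower number from compound 1 to compound 4 (0.07 log units; within the scatter)). This single exchange swaps the aromatic ring and adds a carbon link at once, yet gives no readable shift. Nothing at hand explains this result.

A benzyl group on this nitrogen would separate the added link from the change of ring. Also open, from the compounds shown here alone, is whether trifluoromethyl on the thiophen-2-yl ring, or a longer chain before it, would shift the number.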